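The compounds below may be only part of what the source reports. "The series", "measured", "known", "first", "only" and "open" are said of these compounds alone.

Working notes on the series. In an ADME assay on HUVEC cells (Homo sapiens) for cytotoxicity, read by MTT assay, with a stated time of 24 h (a higher number here means that more compound is tolerated, a lower number that less compound is tolerated), compound 1 `Cc1ccc(/C=C/c2nnc(-c3ccc4c(c3)OCCO4)o2)cc1` gives 265000 nM, compound 2 `O=[N+]([O-])c1ccc(/C=C/c2nnc(-c3ccc4c(c3)OCCO4)o2)cc1` gives 299000 nM and compound 3 `Fc1ccccc1/C=C/c1nnc(-c2ccc3c(c2)OCCO3)o1` gives 402000 nM. The value of compound 3 thus lies within the scatter of both others. Compound 4 `COc1ccc(/C=C/c2nnc(-c3ccc4c(c3)OCCO4)o2)cc1` differs from compound 3 on a double-bonded chain carbon bound to a double-bonded chain carbon: 4-methoxyphenyl in place of 2-fluorophenyl on a double-bonded chain carbon bound to a double-bonded chain carbon. For the measured compounds named here, two measured steps bear on this change, a 1.1-fold higher number from compound 1 to compound 2 (0.05 log units; within the scatter) and a 1.5-fold higher number from compound 1 to compound 3 (0.18 log units; within the scatter). Neither exceeds the scatter, so no step beyond the scatter is expected in this assay. The expected step is a 1.3-fold lower number from compound 3 to compound 4 (0.13 log units; within the scatter). Compound 4 is estimated at 300000 nM, with an expected range of 180000 nM to 500000 nM.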

Compound 4, half-maximal cytotoxic concentration: 312000 nM
Estimate against measurement, compound 4: 1.0-fold (0.02 log units) below; the measured number falls inside the stated range.
By their numbers in this assay, from the lowest: compounds 1, 2, 4 and 3 (each within the scatter of the next).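

Here 4-methoxyphenyl, in place of 2-fluorophenyl on a double-bonded chain carbon bound to a double-bonded chain carbon, stays within the scatter (a 1.3-fold lower number from compound 3 to compound 4 (0.11 log units; within the scatter)) in this assay. Methoxy on the aromatic carbon likewise stays within the scatter against nitro (a 1.0-fold higher number from compound 2 to compound 4 (0.02 log units; within the scatter)) and against methyl (a 1.2-fold higher number from compound 1 to compound 4 (0.07 log units; within the scatter)), so an oxygen-bearing group joins the earlier groups without a step beyond the scatter. No evidence bears on this result.

As far as these compounds go, whether an amine, a carboxylic acid or a longer chain at this place would leave the scatter stays open.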